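This account rests on a few compounds, and the source may have more. Where it says the series, first, only, none or still open, it means among the compounds named here.

In a functional assay on MCF7 cells (Homo sapiens) for inhibition, read by radiometric assay and XTT assay (on this read-out higher numbers stand for weaker inhibition and lower numbers for stronger inhibition), compound 1 `CC/C=C/C=C/[C@@]1(C)SC(O)=CC1=O` returns only a limit, > 80 ug/mL. Two members of the series give actual numbers: compound 2 `CCCCCC[C@@]1(C)SC(=O)C=C1OCC(=O)OCC` gives 39.6 ug/mL, and compound 3 `CCCCCCCC[C@@]1(C)SC(=O)C=C1OCC(=O)OCC` gives 35.3 ug/mL. Among the measured compounds shown here, the single measured step between them is a 1.1-fold lower number from compound 2 to compound 3 (0.05 log units; within the scatter). Compound 3 therefore stands level with compound 2 within the scatter, and together they make up all the numerical data in this set.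

Compound 4 `CCCCCCCC[C@@]1(C)SC(=O)C=C1OC(=O)OCC` has not yet been measured. Its difference from compound 3 is ethoxycarbonyl in place of (ethoxycarbonyl)methyl on an oxygen on an unsaturated carbon. The change therefore leaves the chain and the shared core as they are and alters only the group on that oxygen, shortening (ethoxycarbonyl)methoxy to (ethoxycarbonyl)oxy.

For the measured compounds named here, no measured step touches this oxygen substituent. Going by the values given here, the one available step, a 1.1-fold lower number from compound 2 to compound 3 (0.05 log units; within the scatter), lies on the saturated chain and bears on the question only indirectly, so the data offer no basis for a direction. Compound 3, at 35.3 ug/mL, serves as the anchor for the expectation. The expected step is a 1.1-fold higher number from compound 3 to compound 4 (0.05 log units; within the scatter), which is not expected to exceed the scatter, although the uncertainty is wide. The estimated value for compound 4 is 40 ug/mL, with an expected range from 18 ug/mL to 80 ug/mL.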

Compound 4, half-maximal inhibitory concentration: 15.1 ug/mL
Compound 4: the middle estimate sits 2.6-fold (0.42 log units) above what was measured, outside the stated range (below it).
By their numbers in this assay, from the lowest: compound 4; then compounds 3 and 2 (each within the scatter of the next). At a limit, above all of these: compound 1.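

In this assay, among the compounds shown here, the change from (ethoxycarbonyl)methoxy to (ethoxycarbonyl)oxy gives a 2.3-fold lower number from compound 3 to compound 4 (0.37 log units; beyond the scatter) and so provides the first step in this set that lies beyond the scatter, though only a modest one. The only earlier step, on the saturated chain, was a 1.1-fold lower number from compound 2 to compound 3 (0.05 log units; within the scatter) and so the group on the oxygen on an unsaturated carbon is the one place shown where a single change moves the number beyond the scatter, even though only 6 heavy atoms leave, 5 enter, and the counts of hydrogen-bond donors and acceptors stay the same. Nothing measured in this set bears on why the number moves at this oxygen.

The compounds shown leave open how other groups on this oxygen would read, such as a plain acetyl, an amide or a free carboxylic acid in place of the ethyl ester, and whether ethoxycarbonyl would give a similar step on the shorter chain of compound 2. For the compounds shown here, for compound 1 the value > 80 ug/mL is a limit of the assay and not a number, so it offers no measured step to the other compounds.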